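A few compounds are considered here, and "the series" means these few. Any claim that something is new, unique, unknown or untested is made for them only; others in the source may bear on it.

Measured in an ADME assay on L02 cells (Homo sapiens) for cytotoxicity, read by MTT assay, with a stated time of 48 h; on this read-out higher numbers stand for weaker inhibition and lower numbers for stronger inhibition:

Compound 1 `CCN(CC)c1ccc2cc(C(=O)c3ccc(N4CCN(C(=O)CN5CCNCC5)CC4)cc3)oc2c1` gives > 100000 nM, a limit of the assay.
Compound 2 `CCN(CC)c1ccc2cc(C(=O)c3ccc(N4CCN(C(=O)CN5CCN(S(=O)(=O)c6ccc(F)cc6)CC5)CC4)cc3)oc2c1` gives 9240 nM.
Compound 3 `C#CCN1CCN(CC(=O)N2CCN(c3ccc(C(=O)c4cc5ccc(N(CC)CC)cc5o4)cc3)CC2)CC1` gives > 100000 nM, a limit of the assay.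

Within the data shown here, compound 3 therefore stands at the limit of > 100000 nM in this assay, at which 2 of the 3 values shown sit, and compound 2 is the only member of the set with a number rather than a limit. Compound 4 `CCN(CC)c1ccc2cc(C(=O)c3ccc(N4CCN(C(=O)CN5CCN(Cc6ccc(/C=C/C(=O)OC)cc6)CC5)CC4)cc3)oc2c1` differs from compound 3 in one place: 4-(2-(methoxycarbonyl)ethenyl)phenyl in place of ethynyl on a saturated chain carbon bound to an amine nitrogen in a ring. Among the measured compounds shown here, none of the measured steps repeats this change. The nearest is an at least 10-fold higher number from compound 2 to compound 3 (1.03 log units; beyond the scatter), which turned a readable value into a limit when the aryl sulfonyl left and propargyl arrived; the step that the two limits leave unreadable from compound 1 to compound 3 cannot be read from its two limits. Compound 4 brings an aromatic group back onto this part of the molecule, though bound through a chain carbon rather than a sulfonyl, so a number below the limit seems more likely than not, while the size of any change cannot be set from a single readable compound. Compound 4 is expected to give about 25000 nM in this assay. Its expected range runs from 6000 nM to 100000 nM. That estimate corresponds to an expected step of an at least 4.0-fold lower number from compound 3 to compound 4 (0.60 log units; beyond the scatter).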

Compound 4, half-maximal inhibitory concentration: > 100000 nM
Compound 4 was reported as a limit; the forecaster's own chance of this, stated with the estimate: 40%; middle value at least 4.0-fold (0.60 log units) from the limit.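

In this assay compound 4 gives > 100000 nM, a limit of the assay. Compound 3 also sits at a limit, so no step from compound 3 to compound 4 can be read: the limit of > 100000 nM in this assay, at which 3 of the 4 values shown sit.

The compounds shown leave open how far the values of compound 3 and compound 4 lie apart, or whether they differ at all.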